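Swapping an Ester for a Nitro Group on Compound 3

This account rests on a few compounds, and the source may have more. Where it says the series, first, only, none or still open, it means among the compounds named here.

Of the compounds shown here, three have been measured in an assay on isolated protein for inhibition of serine protease 1 (Bos taurus); a higher number here means a weaker inhibitor, a lower number a stronger inhibitor. Compound 1 `CC(=N)N1CCC(Oc2ccc(NCc3ccc4ccc(C(=N)N)cc4c3)cc2[N+](=O)[O-])CC1` gives 7 nM, compound 2 `CC(=N)N1CCC(Oc2ccc(N(C/C=C/c3cccc(C(=N)N)c3)C(=O)CCC(=O)O)cc2C(F)(F)F)CC1` gives 110 nM, and compound 3 `CCOC(=O)c1cc(NC/C=C/c2cccc(C(=N)N)c2)ccc1OC1CCN(C(C)=N)CC1` gives 40 nM. Compound 3 thus holds the second highest number of the three: compound 2 sits above it and compound 1 below it, both gaps beyond the usual scatter. Compound 4 `CC(=N)N1CCC(Oc2ccc(NC/C=C/c3cccc(C(=N)N)c3)cc2[N+](=O)[O-])CC1` differs from compound 3 in one place (nitro in place of ethoxycarbonyl on an aromatic carbon). A modest step toward a lower number is expected, a 2.7-fold lower number from compound 3 to compound 4 (0.43 log units; beyond the scatter), because compound 1 with its nitro group gives 7 nM in this assay. Compound 4 is therefore estimated at 15 nM, within a range from 5 nM to 50 nM.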

Compound 4, inhibition constant: 27 nM
Compound 4: middle estimate off by 1.8-fold (0.26 log units), on the low side; the range from low to high includes it.
By their numbers in this assay, from the lowest: compound 1; then compounds 4 and 3 (each within the scatter of the next); then compound 2.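

Nitro in place of ethoxycarbonyl is the first single change at this position that can be read, and in this assay it gives a 1.5-fold lower number from compound 3 to compound 4 (0.17 log units; within the scatter) and so does not separate the two groups. Going from five heavy atoms to three on this aromatic carbon therefore leaves the number within the scatter. No available measurement explains this result. Going by these compounds, whether an amine, a carboxylic acid or a longer ester chain on this same carbon would also stay within the scatter remains open.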